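Replacing hydroxymethyl with chloro in compound 3

The compounds below may be only part of what the source reports. "The series", "measured", "known", "first", "only" and "open" are said of these compounds alone.

Of the compounds shown here, three sharing one core have been measured in a physicochemical assay for lipophilicity, read by HPLC, at pH 7.5; a lower number here means a more polar compound, a higher number a more lipophilic compound. Compound 1 `CC[C@@H](Nc1c(C#N)c(-c2ccc(-c3ccccc3F)cc2)nc2cnccc12)C(N)=O` gives 2.7, and compound 2 `CC[C@@H](Nc1c(C#N)c(-c2ccc(-c3ccc(F)cc3)cc2)nc2cnccc12)C(N)=O` gives 2.7. Compound 3 `CC[C@@H](Nc1c(C#N)c(-c2ccc(-c3ccccc3CO)cc2)nc2cnccc12)C(N)=O` gives 2.1, the lowest of the three numbers.

Compound 4 `CC[C@@H](Nc1c(C#N)c(-c2ccc(-c3ccccc3Cl)cc2)nc2cnccc12)C(N)=O` differs from compound 3 by a single swap: chloro in place of hydroxymethyl on an aromatic carbon.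

For the measured compounds named here, two measured steps bear most directly on this swap, as both bring hydroxymethyl in where a fluorinated ring had none: a number 0.60 log units lower from compound 1 to compound 3 (beyond the scatter) and a number 0.60 log units lower from compound 2 to compound 3 (beyond the scatter). The swap of 2-fluorophenyl for 4-fluorophenyl gave no change at the digits printed from compound 1 to compound 2 (within the scatter). The new swap takes hydroxymethyl out again, so a modest move upward, of similar size or slightly larger, is expected. Going by the values given here, no compound with chloro has been measured yet, which makes this only a rough guide. The expected change is a number 0.80 log units higher from compound 3 to compound 4 (beyond the scatter). For compound 4 the estimated value is 2.9, with an expected range from 2.5 to 3.3.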

Compound 4, distribution coefficient: 2.9
The estimate for compound 4 equals the measured number at the digits printed, and the stated range covers the measured number.
By their numbers in this assay, from the lowest: compound 3; then compounds 1, 2 and 4 (each within the scatter of the next).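

In this assay, chloro in place of hydroxymethyl on this aromatic carbon, ortho to a large group, gives a number 0.80 log units higher from compound 3 to compound 4 (beyond the scatter), so the lower number of compound 3 does not carry over to this second halogen-bearing ring. Chloro in place of fluoro at the same place gives a number 0.20 log units higher from compound 1 to compound 4 (within the scatter), and 2-chlorophenyl in place of 4-fluorophenyl gives a number 0.20 log units higher from compound 2 to compound 4 (within the scatter), so among these four compounds only hydroxymethyl sets a compound apart, while the two halogens cannot be told apart. Nothing shown here explains these numbers.

The compounds shown leave open how an amine, a carboxylic acid or a longer chain such as hydroxyethyl would read at this place in this assay. They also leave open whether hydroxymethyl or chloro would behave the same way elsewhere on this ring.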